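Hydroxy to amino exchange in a stilbene series

A few compounds are considered here, and "the series" means these few. Any claim that something is new, unique, unknown or untested is made for them only; others in the source may bear on it.

Measured compounds in a functional assay on HT-29 cells (Homo sapiens) for inhibition, read by MTT assay, with a stated time of 2 days; a higher number here means a weaker inhibitor, a lower number a stronger inhibitor:
compound 1, `Oc1ccccc1/C=C/c1ccccc1O`, 25 ug/mL
compound 2, `Nc1ccccc1/C=C/c1ccccc1O`, 36 ug/mL
compound 3, `Oc1ccc(/C=C/c2cccc(O)c2)cc1`, 6.9 ug/mL

Compound 3 gives the lowest of the three numbers; the two others stand beyond the scatter from it. Compound 1 and compound 3 share the same atoms joined differently; the difference between the two cores is not broken down here.

Compound 2 carries on the core of compound 1 one change, (amino in place of hydroxy on an aromatic carbon). The step it made, a 1.4-fold higher number from compound 1 to compound 2 (0.16 log units; within the scatter), is within the scatter, so the two values show no order between them.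

Compound 4, `Nc1ccc(/C=C/c2cccc(O)c2)cc1`, is not yet measured. It differs from compound 3 by amino in place of hydroxy on an aromatic carbon. This is the same kind of change as from compound 1 to compound 2, but not the same: there the entering amino sits ortho to a group of 9 heavy atoms, here it sits para to a group of 9 heavy atoms. Among the compounds with values here, only one measured instance of the change exists, so the expectation rests on that single step alone.

Within the data shown here, for compound 4 a step of about a 1.4-fold higher number from compound 3 to compound 4 (0.14 log units; within the scatter) is expected, resting on the step of a 1.4-fold higher number from compound 1 to compound 2 (0.16 log units; within the scatter) as the only guide. In this assay compound 4 is estimated at 9.5 ug/mL, with a likely range from 4.5 ug/mL to 20 ug/mL.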

Compound 4, half-maximal inhibitory concentration: 42 ug/mL
The estimate for compound 4 lay 4.4-fold (0.65 log units) below the measured number; measured number outside the range, above it.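

In this assay the exchange of hydroxy for amino on an aromatic carbon gives a 6.1-fold higher number from compound 3 to compound 4 (0.78 log units; beyond the scatter) and thus a clear separation on this core, whereas the same exchange on the core of compound 1 gave two values with no order between them. The size of the step therefore does not carry from one core to the other in this series, and a single instance is a poor guide to a second one: the same change on two cores in this assay, a 1.4-fold higher number (0.16 log units; within the scatter) from compound 1 to compound 2 and a 6.1-fold higher number (0.78 log units; beyond the scatter) from compound 3 to compound 4, 4.2-fold (0.63 log units) apart, beyond the scatter of two such steps

What the two steps do not show is the reason for the gap, since the cores differ and the entering amino sits para to a group of 9 heavy atoms only in compound 4, so the core and the place of the exchange cannot be told apart with two instances.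

From the compounds shown here alone, it remains open whether the step on the core of compound 3 follows from the entering amino or from the loss of the hydroxy, which a methoxy group or an acetamide at the same place could separate. Going by these compounds, it is also open whether a fluorine or a methoxy group in place of the remaining hydroxy of compound 3 would give a step of similar size.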